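The compounds below may be only part of what the source reports. "The series", "measured", "known", "first", "only" and "open" are said of these compounds alone.

Measured compounds:
compound 1, `C#Cn1ccnc1C#Cc1ccc(OC)cc1`, 500 nM
compound 2, `C#Cn1ccnc1C#Cc1ccc(C(C)(C)C)cc1`, 2500 nM
compound 3, `C#Cn1ccnc1C#Cc1ccc(C(C)=O)cc1`, 500 nM

All three values come from a functional assay on A549 cells (Homo sapiens) for cytotoxicity, read by resazurin assay, with a stated time of 72 h; on this read-out lower numbers stand for stronger inhibition and higher numbers for weaker inhibition. Compound 3 stands level with compound 1, the pair giving the lowest numbers of the three; the gap to compound 2 is beyond the scatter, as the step of a 5.0-fold lower number from compound 2 to compound 3 (0.70 log units; beyond the scatter) shows.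

Compound 4, `C#Cn1ccnc1C#Cc1ccc([N+](=O)[O-])cc1`, differs from compound 3 by nitro in place of acetyl on an aromatic carbon. For the measured compounds named here, no measured step involves a nitro group. The nearest comparisons are the exchange no change at the digits printed from compound 1 to compound 3 (within the scatter), within the scatter, and the exchange a 5.0-fold lower number from compound 2 to compound 3 (0.70 log units; beyond the scatter). Going by the values given here, with no nitro example to lean on, the expected step is small: no change at the digits printed from compound 3 to compound 4 (within the scatter). Compound 4 is therefore estimated at 500 nM, with a range from 200 nM to 1500 nM.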

Compound 4, half-maximal inhibitory concentration: 120 nM
The estimate for compound 4 lay 4.2-fold (0.62 log units) above the measured number, outside the stated range (below it).
By their numbers in this assay, from the lowest: compound 4; then compounds 1 and 3 (each within the scatter of the next); then compound 2.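

In this assay nitro on this aromatic carbon goes past the level that methoxy and acetyl share, with a 4.2-fold lower number from compound 1 to compound 4 (0.62 log units; beyond the scatter) against methoxy and a 4.2-fold lower number from compound 3 to compound 4 (0.62 log units; beyond the scatter) against acetyl at this position. Against tert-butyl the span grows to a 21-fold lower number from compound 2 to compound 4 (1.32 log units; beyond the scatter) overall, so this position separates groups more widely than compounds 1, 2 and 3 alone showed. Acetyl and nitro have the same heavy-atom count, so that count alone does not set the number, and nothing measured here says why nitro gives this result.

On these data alone, whether a nitrile or a carboxylic acid on this carbon would match nitro stays open, as does whether an amine would fall nearer to tert-butyl.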